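The source may hold more compounds than are shown below. What is called first, only, known or untested is meant among the compounds shown, and "the series" means these compounds.

The measured compounds:
compound 1, `C=C(C)C(CC=C(C)C)C[C@@]12C[C@@H](C[C@H](O)C(C)(C)OC)C(C)(C)[C@@](CC=C(C)C)(C(=O)C(C(=O)c3ccc(O)c(O)c3)=C1O)C2=O`, gives > 10000 nM in an ADME assay on L02 cells (Homo sapiens) for cytotoxicity, read by MTT assay; a higher number here means a weaker inhibitor, a lower number a stronger inhibitor
compound 2, `C=C(C)C(C[C@@H](O)C(=C)C)C[C@@]12C[C@@H](CC=C(C)C)C(C)(C)[C@@](CC=C(C)C)(C(=O)C(C(=O)c3ccc(O)c(O)c3)=C1O)C2=O`, gives > 10000 nM in this assay

Both of these values are limits of this assay rather than numbers. Compound 1 sits at the limit with > 10000 nM. Compound 2 likewise sits at the limit with > 10000 nM. So compound 2 stands exactly where every value shown stands, namely at the limit of > 10000 nM in this assay, at which 2 of the 2 values shown sit; no number separates it from compound 1.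

Compound 3, `C=C(C)C(C[C@H](O)C(=C)C)C[C@@]12C[C@@H](CC=C(C)C)C(C)(C)[C@@](CC=C(C)C)(C(=O)C(C(=O)c3ccc(O)c(O)c3)=C1O)C2=O`, has not yet been measured. It differs from compound 2 in a single respect: the two compounds have the same atoms and bonds; at least one stereo element is drawn with a configuration in one of them and without one in the other: 1 of 5 stereo elements differ; a stereocentre at a saturated chain carbon is drawn R in compound 2 and S in compound 3. Among the compounds with values here, no step between two measured compounds is available, so nothing fixes the size of such a change. Since both measured compounds sit at the limit (the limit of > 10000 nM in this assay, at which 2 of the 2 values shown sit), no direction of change beyond the scatter is indicated by the data. Compound 3 is therefore expected to give about 20000 nM in this assay, with a likely range from 8000 nM to 60000 nM, and most probably to be reported again only as a limit. The estimated step that the limit leaves unreadable from compound 2 to compound 3 is expected to be none beyond the scatter.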

Compound 3, half-maximal inhibitory concentration: > 10000 nM
Compound 3 ended at the assay's limit (the forecaster's own chance of this, stated with the estimate: 85%); the middle value is on the limit's open side.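

No step from compound 2 to compound 3 can be read in this assay, because both values are limits of the assay rather than numbers: the limit of > 10000 nM in this assay, at which 3 of the 3 values shown sit.

The compounds shown leave open whether the configuration at the saturated chain carbon, drawn R in compound 2 and S in compound 3, changes the read-out in this assay at all.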